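Diethylcarbamoyl on the Pyridine Ring of a Potent Ether

The source may hold more compounds than are shown below. What is called first, only, known or untested is meant among the compounds shown, and "the series" means these compounds.

Measured compounds:
compound 1 `CN1CCC[C@H]1COc1cccnc1`, 0.15 nM
compound 2 `CN1CCC[C@H]1COc1cccnc1[N+](=O)[O-]`, 9000 nM

In an assay on membranes from brain for displacement of a labelled ligand from Neuronal acetylcholine receptor; alpha4/beta2 (Rattus norvegicus) (a higher number here means a weaker inhibitor, a lower number a stronger inhibitor), compound 1 stands lowest of the two numbers shown, and its nearest neighbour is compound 2. Within the data shown here, the only measured step is a 60000-fold higher number from compound 1 to compound 2 (4.78 log units; beyond the scatter), a substitution at a different aromatic carbon from the one changed here. Compound 3 `CCN(CC)C(=O)c1ccncc1OC[C@@H]1CCCN1C` differs from compound 1 by diethylcarbamoyl in place of hydrogen on an aromatic carbon, the new group sitting opposite the ring nitrogen. Among the measured compounds shown here, no measured step tests this position, so the nitro step can only show that the shared core of compound 1 does not tolerate every substituent; it cannot be transferred directly. The entering group is larger than a nitro group, and the position differs, so a loss is expected but of uncertain size. Compound 3 is therefore estimated at 100 nM, in a range from 5 nM to 3000 nM, which would be a 670-fold higher number from compound 1 to compound 3 (2.82 log units; beyond the scatter).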

Compound 3, inhibition constant: 2830 nM
Estimate against measurement, compound 3: 28-fold (1.45 log units) below; the range from low to high includes it.
By their numbers in this assay, from the lowest: compound 1; then compound 3; then compound 2.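

In this assay, among these compounds, diethylcarbamoyl on the aromatic carbon opposite the ring nitrogen gives (a 19000-fold higher number from compound 1 to compound 3 (4.28 log units; beyond the scatter)), the first reading at this position. Among the compounds shown here, the shared core therefore loses strongly with a substituent on this carbon as well as on the one carrying the nitro group in compound 2, so that loss is not confined to a single aromatic carbon. Nothing given here explains the size of the change at this position.

With diethylcarbamoyl as the only group shown at this position, the compounds do not separate the effect of the position from that of this particular group. A single fluorine, a methyl or a primary carboxamide on the same carbon would show whether any substituent there is poorly accepted or whether the loss belongs to diethylcarbamoyl itself.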